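Removing a Chloro Group from an Inactive Hydrazone

The source may report more compounds than this note shows. Statements on the series, on what has been measured and on what is new or still open speak of the compounds shown alone.

Compound 1 `COc1ccc(OC)c(/C=C/c2nnc(Nc3ccc(Cl)cc3)o2)c1` and compound 2 `COc1ccc(OC)c(/C=C/C(=O)N/N=C/c2ccc(Cl)cc2)c1` belong to the same series. In a functional assay on BT-549 cells (Homo sapiens) for antiproliferative activity, read by sulforhodamine B assay, with a stated time of 48 h (on this read-out higher numbers stand for weaker inhibition of growth and lower numbers for stronger inhibition of growth), compound 1 gives > 100000 nM, which is a limit of the assay rather than a number. In this assay compound 2 likewise gives > 100000 nM, again only a limit. Within the data shown here, compound 2 therefore stands at the limit of > 100000 nM in this assay, at which 2 of the 2 values shown sit, so no measured step is available. Compound 3 `COc1ccc(OC)c(/C=C/C(=O)N/N=C/c2ccccc2)c1` differs from compound 2 by hydrogen in place of chloro on an aromatic carbon. No change beyond the scatter is expected, and the step is estimated as a number no higher from compound 2 to compound 3 (the limit leaves the size open). Compound 3 is expected to give about 100000 nM, between 30000 nM and 300000 nM.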

Compound 3, concentration for total growth inhibition: 90400 nM
Beside the measured number, compound 3's estimate is 1.1-fold (0.04 log units) above it; the measured number falls inside the stated range.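

Among the compounds shown, compound 3 alone gives a real number in this assay rather than a limit. Exchanging 4-chlorophenyl for phenyl gives an at least 1.1-fold lower number from compound 2 to compound 3 (0.04 log units; that floor lies within the scatter), so nothing here shows that the chloro group is needed for the growth inhibition seen with compound 3. Only a floor can be given for this step because compound 2 sits at a limit: the limit of > 100000 nM in this assay, at which 2 of the 3 values shown sit.

Still open, on these data alone, is how a methoxy group, a hydroxyl group or an amine in place of the chloro group would read in this assay. As far as these compounds go, whether any such group would give a clearly lower number also remains unknown.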